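The compounds below may be only part of what the source reports. "The series", "measured", "known", "first", "only" and "open" are said of these compounds alone.

In an ADME assay on MT4 cells (Homo sapiens) for cytotoxicity, read by MTT assay, with a stated time of 5 days (on this read-out higher numbers stand for lower toxicity in this test and lower numbers for higher toxicity in this test), three compounds share one core and differ in the group on a saturated chain carbon bound to an amine nitrogen in a ring. Compound 1 `Cc1cc(C)cc(S(=O)(=O)c2c(C(=O)N[C@@H]3CCN(Cc4n[nH]c(=O)n4C)C3)[nH]c3ccc(Cl)cc23)c1` gives 22400 nM. Compound 2 `Cc1cc(C)cc(S(=O)(=O)c2c(C(=O)N[C@@H]3CCN(Cc4ccccc4F)C3)[nH]c3ccc(Cl)cc23)c1` reads > 231000 nM, which is a limit of the assay and not a number. Compound 3 `Cc1cc(C)cc(S(=O)(=O)c2c(C(=O)N[C@@H]3CCN(Cc4ccccc4C#N)C3)[nH]c3ccc(Cl)cc23)c1` reads >= 186000 nM, which is also a limit and not a number.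

The measured steps are an at least 10-fold higher number from compound 1 to compound 2 (1.01 log units; beyond the scatter) and an at least 8.3-fold higher number from compound 1 to compound 3 (0.91 log units; beyond the scatter), and the last is a step that the two limits leave unreadable from compound 2 to compound 3. All three swap groups, and none alters a stereocentre, so they give no size for the next change.

Compound 4 `Cc1cc(C)cc(S(=O)(=O)c2c(C(=O)N[C@H]3CCN(Cc4ccccc4C#N)C3)[nH]c3ccc(Cl)cc23)c1` alters only the drawn shape: the two compounds have the same atoms and bonds and differ only in configuration as drawn: 1 of 1 stereo elements differ; a stereocentre at a saturated ring carbon is drawn R in compound 3 and S in compound 4. Among the measured compounds shown here, with no measured step of this kind, no change beyond the scatter is expected in this assay, and no direction can be favoured. The expectation therefore rests on compound 3 and its limit of >= 186000 nM. The estimated step is an at least 1.0-fold lower number from compound 3 to compound 4 (0.03 log units; that floor lies within the scatter). For compound 4 the expected value is 170000 nM, with an estimated range from 60000 nM to 280000 nM.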

Compound 4, half-maximal cytotoxic concentration: > 228000 nM
Compound 4 ended at the assay's limit (the forecaster's own chance of this, stated with the estimate: 65%); middle value at least 1.3-fold (0.12 log units) from the limit.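

Compound 3 and compound 4 both end at limits of this assay, not at numbers, so no step can be read between them. The compounds shown leave open whether the configuration at that saturated ring carbon changes the read-out at all, and in which direction.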